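From anilino to benzylamino: a step not yet measured

This account rests on a few compounds, and the source may have more. Where it says the series, first, only, none or still open, it means among the compounds named here.

Compound 1 `CC(O)(c1ccc(-c2ccc(S(=O)(=O)c3ccc(N)nc3)nc2NC2CCCCC2)nc1)C(F)(F)F`: 280 mL.min-1.g-1
Compound 2 `CC(O)(c1ccc(-c2ccc(S(=O)(=O)c3ccc(N)nc3)nc2Nc2ccccc2)nc1)C(F)(F)F`: 100 mL.min-1.g-1

In an ADME assay (liver) for metabolic stability, with Liver microsome (Rattus norvegicus) as the target, using microsomes and NADPH, with a stated time of 30 min, at 37 degrees C, tested at 1 uM (a lower number here means slower removal, a higher number faster removal of the compound), compound 2 holds the lower of the two numbers, at 100 mL.min-1.g-1. Compound 3 `CC(O)(c1ccc(-c2ccc(S(=O)(=O)c3ccc(N)nc3)nc2NCc2ccccc2)nc1)C(F)(F)F` has benzyl in place of phenyl on a nitrogen on an aromatic ring. For the measured compounds named here, the only measured step at that place is a 2.8-fold lower number from compound 1 to compound 2 (0.45 log units; beyond the scatter), with phenyl in place of cyclohexyl. It is a different exchange, so it offers only a rough guide to size. A modest rise is expected, with the estimated step being a 1.7-fold higher number from compound 2 to compound 3 (0.23 log units; within the scatter). The estimate for compound 3 is 170 mL.min-1.g-1, with an expected range of 70 mL.min-1.g-1 to 400 mL.min-1.g-1.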

Compound 3, intrinsic clearance in microsomes: 114 mL.min-1.g-1
Beside the measured number, compound 3's estimate is 1.5-fold (0.17 log units) above it; the range from low to high includes it.
By their numbers in this assay, from the lowest: compounds 2 and 3 (each within the scatter of the next); then compound 1.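

In this assay, benzyl in place of phenyl on a nitrogen on an aromatic ring comes to a 1.1-fold higher number from compound 2 to compound 3 (0.06 log units; within the scatter) and so cannot be told from the scatter. Benzyl in place of cyclohexyl gives a 2.5-fold lower number from compound 1 to compound 3 (0.39 log units; beyond the scatter) and so the gap from cyclohexyl now holds for two groups carrying an aromatic ring of carbon only, not for phenyl alone. Open, from the compounds shown here alone, is whether a longer chain such as phenethyl, or a saturated cyclohexylmethyl group, would follow compound 2 and compound 3 or compound 1. Nothing measured here accounts for these numbers.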